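Alkynyl uracil series: bromophenyl variant of compound 3

A few compounds are considered here, and "the series" means these few. Any claim that something is new, unique, unknown or untested is made for them only; others in the source may bear on it.

Measured so far in a functional assay on SW-620 cells (Homo sapiens) for antiproliferative activity, read by MTT assay, with a stated time of 72 h; a lower number here means a stronger inhibitor, a higher number a weaker inhibitor:
- compound 1 `CC(=O)OCC(CCn1cc(C#Cc2cc(F)cc(F)c2)c(=O)n(C(=O)c2ccccc2)c1=O)COC(C)=O`; compound 1 gives > 100000 nM, which is a limit of the assay.
- compound 2 `CC(=O)OCC(CCn1cc(C#CC(C)(C)C)c(=O)n(C(=O)c2ccccc2)c1=O)COC(C)=O`; compound 2 gives > 100000 nM, which is a limit of the assay.
- compound 3 `O=c1[nH]c(=O)n(CCC(CO)CO)cc1C#Cc1cc(F)cc(F)c1`; compound 3 gives > 100000 nM, which is a limit of the assay.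

Going by the values given here, every value so far sits at the limit of > 100000 nM in this assay, at which 3 of the 3 values shown sit, so no number is available for any compound. Among the compounds with values here, the only change between measured compounds, a step that the two limits leave unreadable from compound 1 to compound 2, cannot be sized, since both ends are limits. Compound 3 therefore stands at the limit, with no readable step to any other compound.

Compound 4 `O=c1[nH]c(=O)n(CCC(CO)CO)cc1C#Cc1ccc(Br)cc1` differs from compound 3 by 4-bromophenyl in place of 3,5-difluorophenyl on a triple-bonded carbon. Within the data shown here, no measured step bears on this change; the step from compound 1 to compound 2 alters the same difluorophenyl but is unreadable, and compound 3 is the only measured compound that carries the diol chain.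

With nothing read as a number in this assay, compound 4 is expected to remain near the limit as well, estimated at 150000 nM with a range of 30000 nM to 1000000 nM. The expected step from compound 3 to compound 4 is a step that the limit leaves unreadable from compound 3 to compound 4, with no direction that can be claimed beyond the scatter.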

Compound 4, half-maximal inhibitory concentration: > 100000 nM
Compound 4: no number, only a limit (the forecaster's own chance of this, stated with the estimate: 75%); the middle value is on the limit's open side.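

No step from compound 3 to compound 4 can be read, as both ends are limits of the assay, and the series stays at one place: the limit of > 100000 nM in this assay, at which 4 of the 4 values shown sit.

The compounds shown leave open whether any group on the triple-bonded carbon, or any other chain on the shared core, would give a readable number.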